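Turning the Cyclohexyl Methyl Stereocentre of Compound 1

The source may hold more compounds than are shown below. What is called first, only, known or untested is meant among the compounds shown, and "the series" means these compounds.

Measured compounds:
Compound 1, `CC(C)c1c(O[C@H]2CCCC[C@@H]2C)cc(CCc2ccccc2)[nH]c1=O`, in an ADME assay on TZM cells (Homo sapiens) for cytotoxicity; a higher number here means that more compound is tolerated, a lower number that less compound is tolerated: > 300000 nM
Compound 2, `CC1CCCCC1Oc1cc(CCc2ccccc2)[nH]c(=O)c1I`, in this assay: > 300000 nM
Compound 3, `Cc1ccc(Cc2cc(OC3CCCCC3C)c(C(C)C)c(=O)[nH]2)cc1`, in this assay: 99000 nM

Compound 1 gives > 300000 nM in this assay, and this is a limit of the assay rather than a number. Compound 2 likewise gives > 300000 nM in this assay, again a limit. Compound 3 stands apart from the other two in that this assay returns a number for it, 99000 nM. Two of the three compounds therefore sit at the limit of > 300000 nM in this assay, at which 2 of the 3 values shown sit, and compound 1 is one of them.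

The next compound, compound 4, `CC(C)c1c(O[C@H]2CCCC[C@H]2C)cc(CCc2ccccc2)[nH]c1=O`, is related to compound 1 as follows: the two compounds have the same atoms and bonds and differ only in configuration as drawn: 1 of 2 stereo elements differ; a stereocentre at a saturated ring carbon is drawn S in compound 1 and R in compound 4. Nothing leaves and nothing enters. Within the data shown here, no step between two measured compounds separates such a pair of configurations here, so the expected size of the step in this assay cannot be read from a measured analogue. Given that compound 1 is tolerated up to the assay limit, the expected step of a number no higher from compound 1 to compound 4 (the limit leaves the size open) is none beyond the scatter, and the estimate for compound 4 in this assay is 300000 nM, within 150000 nM to 600000 nM.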

Compound 4, half-maximal cytotoxic concentration: 189000 nM
Estimate against measurement, compound 4: 1.6-fold (0.20 log units) above; the measured number falls inside the stated range.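

In this assay compound 4 gives 189000 nM, a number rather than a limit, so the R configuration at this saturated ring carbon yields a value that the assay can read. Turning this single stereocentre gives an at least 1.5-fold lower number from compound 1 to compound 4 (0.20 log units; that floor lies within the scatter), and that figure is a floor and not a measured size. Nothing leaves or enters in this change, so this pair isolates the configuration at one ring carbon in a way that the earlier compounds, which differ from one another in more than one place, could not: the fact that compounds 1 and 4 differ only in the configuration as drawn

As far as these compounds go, how far the value of compound 1 lies past its limit stays open, and with it whether turning this stereocentre has any effect beyond the scatter at all. Also open, from the compounds shown here alone, is how this assay would respond if the methyl on this ring carbon gave way to another group, such as a hydroxyl or a longer chain, in either configuration.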